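Rearranging the bicyclic group on a urea-type nitrogen

The source may hold more compounds than are shown below. What is called first, only, known or untested is meant among the compounds shown, and "the series" means these compounds.

Measured compounds:
- Compound 1, `Cc1nc2cc(NC(=O)N3CCN(Cc4cccc(Oc5ccc(Cl)cc5)c4)CC3)ccc2o1`, 200 nM
- Compound 2, `O=C(Nc1cncc2ccccc12)N1CCN(Cc2cccc(Oc3ccc(Cl)cc3)c2)CC1`, 8.3 nM
- Compound 3, `O=C(Nc1noc2cnccc12)N1CCN(Cc2cccc(Oc3ccc(Cl)cc3)c2)CC1`, 0.7 nM

In an assay on isolated protein for inhibition of Fatty-acid amide hydrolase 1 (Rattus norvegicus), with a stated time of 60 min (a higher number here means a weaker inhibitor, a lower number a stronger inhibitor), compound 3 gives the lowest number of the three, so it is the strongest inhibitor among them. The two steps that reach it were both large: a 290-fold lower number from compound 1 to compound 3 (2.46 log units; beyond the scatter) and a 12-fold lower number from compound 2 to compound 3 (1.07 log units; beyond the scatter), and also a 24-fold lower number from compound 1 to compound 2 (1.38 log units; beyond the scatter). All three changes concern only the aromatic group attached to the amide-type nitrogen, and together they show that this assay responds strongly to what that group is.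

Compound 4, `O=C(Nc1noc2cccnc12)N1CCN(Cc2cccc(Oc3ccc(Cl)cc3)c2)CC1`, has not been measured. It differs from compound 3 in this way: a group of 9 heavy atoms (6 carbon, 2 nitrogen, 1 oxygen; one five-membered aromatic ring with 2 hetero atoms, one six-membered aromatic ring with 1 hetero atom) in place of a group of 9 heavy atoms (6 carbon, 2 nitrogen, 1 oxygen; one five-membered aromatic ring with 2 hetero atoms, one six-membered aromatic ring with 1 hetero atom), on an amide-type nitrogen. The two compounds are built from the same atoms joined differently, so the shared core and the remaining parts stay untouched.

Within the data shown here, no measured pair compares two such isomers, so the measured steps give the scale of change this position can produce but not its direction. Because compound 3 is already at 0.7 nM, there is more room for the number to rise than to fall. Compound 4 is therefore expected to remain a strong inhibitor, with a step of a 2.9-fold higher number from compound 3 to compound 4 (0.46 log units; beyond the scatter) estimated towards a somewhat higher number. The estimate for compound 4 in this assay is 2 nM, within a range from 0.4 nM to 12 nM.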

Compound 4, half-maximal inhibitory concentration: 22 nM
Beside the measured number, compound 4's estimate is 11-fold (1.04 log units) below it; measured number outside the range, above it.
By their numbers in this assay, from the lowest: compound 3; then compound 2; then compound 4; then compound 1.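

Rearranging the same atoms within the bicyclic group, with nothing added or removed, gives a 31-fold higher number from compound 3 to compound 4 (1.50 log units; beyond the scatter) in this assay, so at this position how the group is joined can matter as well as what it contains. This arrangement also does not carry over the strength of compound 3: a 2.7-fold higher number from compound 2 to compound 4 (0.42 log units; beyond the scatter) puts it behind the isoquinolin-4-yl group, while a 9.1-fold lower number from compound 1 to compound 4 (0.96 log units; beyond the scatter) still puts it ahead of the 2-methyl-1,3-benzoxazol-5-yl group. No measurement here accounts for the effect of the rearrangement. The compounds shown leave open whether a single pyridine ring on the amide-type nitrogen would keep any of this inhibition. They also leave open whether the step between these two isomers would survive replacing the chlorine with fluorine.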